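Para substituent swap on the aryl pyrazoline series

The source may report more compounds than this note shows. Statements on the series, on what has been measured and on what is new or still open speak of the compounds shown alone.

The series shares a core shown by compound 1 `CCC(=O)N1N=C(c2ccccc2)CC1c1ccc(F)cc1`, compound 2 `CCC(=O)N1N=C(c2ccccc2)CC1c1ccc(C)cc1` and compound 3 `CCC(=O)N1N=C(c2ccc(F)cc2)CC1c1ccc(C)cc1`; compound 4 `CCC(=O)N1N=C(c2ccc(C)cc2)CC1c1ccc(C)cc1` has not been measured. In an assay on isolated protein for inhibition of Amine oxidase [flavin-containing] B (Bos taurus) (on this read-out lower numbers stand for stronger inhibition and higher numbers for weaker inhibition), compound 1 gives 1150 nM, compound 2 gives 100000 nM and compound 3 gives 151 nM. The change methyl in place of fluoro on an aromatic carbon produced an 87-fold higher number from compound 1 to compound 2 (1.94 log units; beyond the scatter). Adding fluoro then produced a 660-fold lower number from compound 2 to compound 3 (2.82 log units; beyond the scatter). The difference between the core of compound 1 and the core of compound 3 is not broken down here. Compound 4 arises from compound 3 by methyl in place of fluoro on an aromatic carbon, the same change as between compound 1 and compound 2, at the same place. Because of an 87-fold higher number from compound 1 to compound 2 (1.94 log units; beyond the scatter) a step of similar direction is expected, a 60-fold higher number from compound 3 to compound 4 (1.78 log units; beyond the scatter), though the other ring differs. Compound 4 is estimated at 9000 nM in this assay, between 1500 nM and 50000 nM.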

Compound 4, half-maximal inhibitory concentration: 100000 nM
Beside the measured number, compound 4's estimate is 11-fold (1.05 log units) below it; the measured number lies above the stated range.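

In this assay, methyl in place of fluoro gives a 660-fold higher number from compound 3 to compound 4 (2.82 log units; beyond the scatter), and methyl in place of hydrogen gives no change at the digits printed from compound 2 to compound 4 (within the scatter). The change raises the number on both cores, so its direction carries over, but its size does not: the same change on two cores in this assay, an 87-fold higher number (1.94 log units; beyond the scatter) from compound 1 to compound 2 and a 660-fold higher number (2.82 log units; beyond the scatter) from compound 3 to compound 4, 7.6-fold (0.88 log units) apart, beyond the scatter of two such steps. These two pairs give no rule for the size of the step on a further core, and they do not show what sets the gap between the two steps.

The compounds shown leave open how an amine, a carboxylic acid or a nitrile would read at this place. They also leave open how the series reads with fluoro on both aromatic rings.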